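The source may report more compounds than this note shows. Statements on the series, on what has been measured and on what is new or still open speak of the compounds shown alone.

Compound 2 `CC(Cl)C(=O)Nc1cccc(-c2nc3ccccc3s2)c1` belongs to a small set of compounds built on one shared core. In an ADME assay on BJ cells (Homo sapiens) for inhibition, with a stated time of 72 h (on this read-out lower numbers stand for an effect already at smaller amounts and higher numbers for an effect only at larger amounts of compound), compound 2 gives > 25000 nM, which is a limit of the assay rather than a number. Its close relative compound 1 `C=C(C)C(=O)Nc1cccc(-c2nc3ccccc3s2)c1` also gives only a limit in this assay, namely > 25000 nM. Going by the values given here, the single measured step, a step that the two limits leave unreadable from compound 1 to compound 2, cannot be read because both ends sit at the limit of > 25000 nM in this assay, at which 2 of the 2 values shown sit. Compound 3 `O=C(Nc1cccc(-c2nc3ccccc3s2)c1)c1cnccc1Cl` differs from compound 2 by 4-chloropyridin-3-yl in place of 1-chloroethyl on a carbonyl carbon. Among the compounds with values here, no measured step bears on this change, so the expected step of a number no higher from compound 2 to compound 3 (the limit leaves the size open) rests only on the two limits. Compound 3 is expected to give about 25000 nM, within 8000 nM to 60000 nM.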

Compound 3, half-maximal effective concentration: > 25000 nM
Compound 3 was reported as a limit; the forecaster's own chance of this, stated with the estimate: 75%; the middle value lies on the limit itself.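

The steps from compound 1 and from compound 2 to compound 3 cannot be read, since each compound gives only a limit: the limit of > 25000 nM in this assay, at which 3 of the 3 values shown sit. From the compounds shown here alone, how the three groups on the carbonyl carbon compare in this assay stays open.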